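Hydrogen in Place of Methyl on the Anilino Ring

The compounds below may be only part of what the source reports. "The series", "measured", "known", "first", "only" and "open" are said of these compounds alone.

Compound 2 `Cc1ccccc1Nc1nc(SCc2cn(Cc3ccccc3Cl)nn2)nc(-c2ccccc2)c1C#N` gives 7280 nM in a functional assay on MGC-803 cells (Homo sapiens) for inhibition, read by MTT assay, with a stated time of 72 h (on this read-out higher numbers stand for weaker inhibition and lower numbers for stronger inhibition), and compound 1 `N#Cc1c(Nc2ccccc2Cl)nc(SCc2cn(Cc3ccccc3Cl)nn2)nc1-c1ccccc1` gives 4640 nM in this assay, a number that lies within the scatter of compound 2. Compound 3 `N#Cc1c(Nc2ccccc2)nc(SCc2cn(Cc3ccccc3Cl)nn2)nc1-c1ccccc1` differs from compound 2 by hydrogen in place of methyl on an aromatic carbon, on an aromatic carbon ortho to a large group, turning the (2-methylphenyl)amino group into anilino. For the measured compounds named here, the only step that touches this carbon, a 1.6-fold higher number from compound 1 to compound 2 (0.20 log units; within the scatter), stayed within the scatter, so no step beyond the scatter is expected here either, a 1.3-fold lower number from compound 2 to compound 3 (0.12 log units; within the scatter). Compound 3 is therefore estimated at 5500 nM, between 2500 nM and 12000 nM.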

Compound 3, half-maximal inhibitory concentration: > 64000 nM
Compound 3: only a limit was reported; the forecaster's own chance of this, stated with the estimate: 5%; middle value at least 11-fold (1.06 log units) from the limit.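

Compound 3 is reported only as a limit: the limit of > 64000 nM in this assay, at which 1 of the 3 values shown sits. Methyl and chloro could not be told apart on this aromatic carbon, but hydrogen in place of methyl gives an at least 8.7-fold higher number from compound 2 to compound 3 (0.94 log units; beyond the scatter), and hydrogen in place of chloro gives an at least 13-fold higher number from compound 1 to compound 3 (1.13 log units; beyond the scatter). The position is therefore not indifferent to change, since the anilino compound stands clearly apart from both substituted compounds.

From the compounds shown here alone, whether a methoxy group, an ethyl group or an amine on this carbon would match methyl and chloro remains open.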